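From formyl to acetyl on compound 2

The compounds below may be only part of what the source reports. "The series", "measured", "known", "first", "only" and "open" are said of these compounds alone.

Measured in an ADME assay on microsomes from liver (Homo sapiens) for metabolic stability; a lower number here means slower removal, a higher number faster removal of the compound:
compound 1 `CN(C(=O)[C@H]1CN(S(=O)(=O)c2ccccc2)C[C@@H]1NC(=O)c1cc(-c2ccccc2Cl)on1)[C@H]1CCCNC1`: 4.2 mL.min-1.g-1
compound 2 `O=CN1CCC[C@H](NC(=O)[C@H]2CN(S(=O)(=O)c3ccccc3)C[C@@H]2NC(=O)c2cc(-c3ccccc3Cl)on2)C1`: > 259 mL.min-1.g-1

Compound 2 reads > 259 mL.min-1.g-1, which is a limit of the assay and not a number.

Compound 3 `CC(=O)N1CCC[C@H](NC(=O)[C@H]2CN(S(=O)(=O)c3ccccc3)C[C@@H]2NC(=O)c2cc(-c3ccccc3Cl)on2)C1` differs from compound 2 by methyl in place of hydrogen on a carbonyl carbon, or formyl to acetyl. Going by the values given here, the only measured step, an at least 61-fold higher number from compound 1 to compound 2 (1.79 log units; beyond the scatter), is large, but it is a different change and ends in a limit, so it sets no size here. Only a moderate fall in this assay is expected, and it may not clear the scatter. The expected change is an at least 1.9-fold lower number from compound 2 to compound 3 (0.29 log units; that floor lies within the scatter). Compound 3 is estimated at 130 mL.min-1.g-1, within a range from 35 mL.min-1.g-1 to 400 mL.min-1.g-1.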

Compound 3, intrinsic clearance in microsomes in the Homo sapiens assay: > 300 mL.min-1.g-1
Compound 3 gave a limit, no number (the forecaster's own chance of this, stated with the estimate: 30%); middle value at least 2.3-fold (0.36 log units) from the limit.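

In the Homo sapiens assay compound 3 gives a limit of the assay, not a number: the limit of > 300 mL.min-1.g-1 in the Homo sapiens assay, at which 1 of the 3 values shown sits. With compound 2 also at a limit, the step between the two cannot be read; in the Homo sapiens assay the readable step is an at least 71-fold higher number from compound 1 to compound 3 (1.85 log units; beyond the scatter), so acetyl, like formyl, stands far from compound 1 on this read-out. In a physicochemical assay for solubility, at pH 7.4 (on this read-out lower numbers stand for lower solubility and higher numbers for higher solubility), compound 2 gives 4500 nM. In the physicochemical assay compound 3 gives < 500 nM, which is a limit of the assay, not a number: the limit of < 500 nM in the physicochemical assay, at which 1 of the 2 values shown sits. In the physicochemical assay the same change reads an at least 9.0-fold lower number from compound 2 to compound 3 (0.95 log units; beyond the scatter).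

Going by these compounds, whether a methoxy or an amine on this carbonyl carbon would bring the Homo sapiens assay back towards compound 1 stays open. So do actual numbers there for compound 2 and compound 3.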